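This account rests on a few compounds, and the source may have more. Where it says the series, first, only, none or still open, it means among the compounds named here.

In a functional assay on MV4-11 cells (Homo sapiens) for antiproliferative activity, read by CCK-8 assay, with a stated time of 72 h (a lower number here means a stronger inhibitor, a higher number a weaker inhibitor), compound 1 `Cn1cc(-c2ccccc2Oc2ccccc2)c2cc(C(=O)NCc3ccc(C(=O)Nc4ccccc4N)cc3)[nH]c2c1=O` gives 80 nM, compound 2 `Cn1cc(-c2ccccc2F)c2cc(C(=O)NCc3ccc(C(=O)Nc4ccccc4N)cc3)[nH]c2c1=O` gives 230 nM, and compound 3 `CC(C)Oc1ccc(C(C)(C)O)cc1-c1cn(C)c(=O)c2[nH]c(C(=O)NCc3ccc(C(=O)Nc4ccccc4N)cc3)cc12` gives 40 nM. Compound 3 and compound 1 lie within the usual scatter of each other, while compound 2 lies beyond the scatter from compound 3.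

Compound 4 `CC(C)Oc1ccccc1-c1cn(C)c(=O)c2[nH]c(C(=O)NCc3ccc(C(=O)Nc4ccccc4N)cc3)cc12` differs from compound 3 in one place: hydrogen in place of 1-hydroxy-1-methylethyl on an aromatic carbon. The isopropoxy group stays. Among the compounds with values here, no measured step removes this group, so the evidence is only indirect. Within the data shown here, the one measured step, a 2.9-fold higher number from compound 1 to compound 2 (0.46 log units; beyond the scatter), puts fluoro in place of phenoxy on an aromatic carbon, and it is modest. That step shows that a single swap of this kind can shift the number, though it is a different swap. Among the measured compounds shown here, a modest rise, no larger than that step, therefore seems a reasonable expectation.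

The estimated step is a 1.8-fold higher number from compound 3 to compound 4 (0.24 log units; within the scatter). For compound 4 the expected value is 70 nM, with an estimated range from 30 nM to 170 nM.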

Compound 4, half-maximal inhibitory concentration: 130 nM
Compound 4: the middle estimate sits 1.9-fold (0.27 log units) below what was measured, and the stated range covers the measured number.
By their numbers in this assay, from the lowest: compounds 3, 1, 4 and 2 (each within the scatter of the next, the first and the last beyond it).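

Within the data shown here, removing the 1-hydroxy-1-methylethyl group from its place para to the isopropoxy group gives a 3.3-fold higher number from compound 3 to compound 4 (0.51 log units; beyond the scatter) in this assay and lies beyond the scatter, so this is the first direct sign that this position matters. With hydrogen at this position, a 1.8-fold lower number from compound 2 to compound 4 (0.25 log units; within the scatter) and a 1.6-fold higher number from compound 1 to compound 4 (0.21 log units; within the scatter) are both within the scatter, so isopropoxy cannot be told apart from either fluoro or phenoxy, even though those two groups differ from each other beyond the scatter. Nothing measured here gives a reason for the effect of the 1-hydroxy-1-methylethyl group.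

Going by these compounds, whether a hydroxymethyl group, an amine or a carboxylic acid at this position would give a number like that of compound 3 remains open. On these data alone, it is also open whether the 1-hydroxy-1-methylethyl group would count the same alongside fluoro or phenoxy.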